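The compounds below may be only part of what the source reports. "The series", "measured", "known", "first", "only" and "open" are said of these compounds alone.

Measured compounds:
compound 1 `O=c1cc(-c2ccccc2)oc2c([N+](=O)[O-])c(O)cc(O)c12`, 12000 nM in an ADME assay on H9 cells (Homo sapiens) for cytotoxicity, with a stated time of 3 days; on this read-out higher numbers stand for weaker inhibition and lower numbers for stronger inhibition
compound 2 `O=c1cc(-c2ccccc2)oc2c([N+](=O)[O-])c(O)c([N+](=O)[O-])c(O)c12`, 372000 nM in this assay

Compound 1 stands at the lowest of the two numbers shown; its nearest neighbour is compound 2, and the step of a 31-fold higher number from compound 1 to compound 2 (1.49 log units; beyond the scatter) was large and beyond the scatter. That step is the only measured one, and it concerns a nitro in place of hydrogen on an aromatic carbon of the shared core, not the change now in question.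

Compound 3 `Nc1c(O)cc(O)c2c(=O)cc(-c3ccccc3)oc12` differs from compound 1 as follows: amino in place of nitro on an aromatic carbon. Among the compounds with values here, no measured step bears directly on this change; the pair of compound 1 and compound 2 shows only that a second nitro moved the number sharply upward, and it says nothing about replacing the existing nitro by amino. The expectation for compound 3 therefore rests on compound 1 alone, with a wide range. A step of a 1.7-fold higher number from compound 1 to compound 3 (0.22 log units; within the scatter) is expected, which is taken to lie within or near the scatter. Compound 3 is estimated at 20000 nM in this assay, with a range from 4000 nM to 100000 nM.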

Compound 3, half-maximal inhibitory concentration: 34000 nM
The estimate for compound 3 lay 1.7-fold (0.23 log units) below the measured number; the range from low to high includes it.
By their numbers in this assay, from the lowest: compound 1; then compound 3; then compound 2.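

In this assay, amino in place of nitro on this aromatic carbon, ortho to a fused ring and ortho to a hydroxy group, gave a 2.8-fold higher number from compound 1 to compound 3 (0.45 log units; beyond the scatter), a modest step but one beyond the scatter. The earlier pair showed only the large step of a 31-fold higher number from compound 1 to compound 2 (1.49 log units; beyond the scatter) on adding a nitro in place of hydrogen, whereas this result shows that exchanging the nitro already on the core for amino also moves the number upward. No measurement shown here accounts for this rise, so the exchange of a nitro with no hydrogen-bond donor for an amino with a hydrogen-bond donor remains an observed difference without an established cause.

The compounds shown leave open whether the rise follows the loss of the nitro or the arrival of the amino, a question that plain hydrogen at this position could help to separate. They also leave open how an acetamide, a methoxy group or a carboxylic acid on the same carbon would read in this assay.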